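Shifting one methyl group: compound 3 awaits its measurement

A few compounds are considered here, and "the series" means these few. Any claim that something is new, unique, unknown or untested is made for them only; others in the source may bear on it.

Compounds in a physicochemical assay for permeability, using PAMPA; a higher number here means that the compound crosses the layer faster, a lower number that the compound crosses the layer more slowly:
- compound 1 `Cc1cccc(-c2nc(CN3CCC(C(=O)NCCCN4C[C@H](C)C[C@H](C)C4)CC3)c(C)o2)c1`: 279 10^-6 cm/s
- compound 2 `Cc1ccc(-c2nc(CN3CCC(C(=O)NCCCN4C[C@H](C)C[C@H](C)C4)CC3)c(C)o2)cc1C`: 219 10^-6 cm/s
- compound 3 `Cc1ccc(-c2nc(CN3CCC(C(=O)NCCCN4C[C@H](C)C[C@H](C)C4)CC3)c(C)o2)c(C)c1`: not yet measured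

The value of compound 2 lies within the scatter of the value of compound 1, so the two cannot be told apart. Compound 3 differs from compound 2 in one place, 2,4-dimethylphenyl in place of 3,4-dimethylphenyl on an aromatic carbon. Among the measured compounds shown here, no measured step shows this exact exchange. The nearest, a 1.3-fold lower number from compound 1 to compound 2 (0.11 log units; within the scatter), put methyl in place of hydrogen on an aromatic carbon and stayed within the scatter. On that evidence, no change beyond the scatter is expected in this assay. The estimated step is a 1.1-fold higher number from compound 2 to compound 3 (0.04 log units; within the scatter). Compound 3 is expected at 240 10^-6 cm/s, with an estimated range of 130 10^-6 cm/s to 420 10^-6 cm/s.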

Compound 3, apparent permeability: 353 10^-6 cm/s
Compound 3: the middle estimate sits 1.5-fold (0.17 log units) below what was measured; the measured number falls inside the stated range.
By their numbers in this assay, from the lowest: compounds 2, 1 and 3 (each within the scatter of the next).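

In this assay, 2,4-dimethylphenyl in place of 3,4-dimethylphenyl gives a 1.6-fold higher number from compound 2 to compound 3 (0.21 log units; within the scatter) and 2,4-dimethylphenyl in place of 3-methylphenyl gives a 1.3-fold higher number from compound 1 to compound 3 (0.10 log units; within the scatter) at the same place on the five-membered aromatic ring. As far as these three compounds go, rearranging methyl groups on this phenyl leaves the number inside the scatter. Nothing given here accounts for these steps. The compounds shown leave open whether a phenyl bearing a methoxy group, a chlorine or a carboxylic acid, or a pyridine in its place, would also stay within the scatter.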